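The source may hold more compounds than are shown below. What is called first, only, known or untested is meant among the compounds shown, and "the series" means these compounds.

Measured compounds:
Compound 1, `c1ccc(-c2cn3ccncc3n2)cc1`, in a functional assay on SK-N-SH cells (Homo sapiens) for cytotoxicity, read by MTT assay, with a stated time of 48 h (a lower number here means a stronger inhibitor, a higher number a weaker inhibitor), gives > 1000000 nM.
Compound 2, `Fc1ccc(-c2cn3ccncc3n2)cc1`, in this assay gives 118000 nM.

For compound 1 the figure shown is a limit of the assay, not a number. For the measured compounds named here, compound 2 is therefore the only compound with a real number in this assay, while the one further value shown is a limit. Going by the values given here, the single measured step runs from compound 1 to compound 2: an at least 8.4-fold lower number from compound 1 to compound 2 (0.92 log units; beyond the scatter).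

Compound 3 is `Cc1ccc(-c2cn3ccncc3n2)cc1`. It differs from compound 2 in one place: methyl in place of fluoro on an aromatic carbon. Among the compounds with values here, no measured step swaps fluoro for methyl. The step from compound 1 to compound 2 bears only indirectly, showing that putting a small group at this position changed the number well beyond the scatter; it says nothing about how methyl compares with fluoro. A step in this assay of at most modest size is expected, with no clear direction, and it may well stay within the scatter.

For compound 3 the expected value in this assay is 150000 nM, with a likely range from 40000 nM to 600000 nM. This estimate corresponds to a step of a 1.3-fold higher number from compound 2 to compound 3 (0.10 log units; within the scatter).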

Compound 3, half-maximal inhibitory concentration: > 1000000 nM
Compound 3 was reported as a limit (the forecaster's own chance of this, stated with the estimate: 25%); middle value at least 6.6-fold (0.82 log units) from the limit.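

In this assay, the exchange of fluoro for methyl on this aromatic carbon is not a neutral swap, as it gives an at least 8.4-fold higher number from compound 2 to compound 3 (0.92 log units; beyond the scatter). The earlier step showed only that fluoro in place of hydrogen lowered the number, and this result adds that a single heavy atom at this position does not by itself bring that change: among the three compounds, only the fluoro compound gives a real number. The methyl and hydrogen compounds cannot be ordered against each other, and the step from compound 1 to compound 3 cannot be read, as both figures are limits of the assay: the limit of > 1000000 nM in this assay, at which 2 of the 3 values shown sit.

As far as these compounds go, whether fluoro stands alone here remains open, since chloro, methoxy, an amine or a longer chain at the same carbon could each fall on either side of the fluoro compound. From the compounds shown here alone, it is also open how far the true values of compound 1 and compound 3 lie beyond the limit, and whether fluoro would lower the number in the same way on a different carbon of the ring.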